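Imidazopyridine series: cytotoxicity, compound 3 to compound 4

The source may report more compounds than this note shows. Statements on the series, on what has been measured and on what is new or still open speak of the compounds shown alone.

Compound 1 `Cc1cc(-n2ccc3ccccc32)cn2c(CSCCc3ccccc3)cnc12` in an ADME assay on HEL cells (Homo sapiens) for cytotoxicity, with a stated time of 3 days (a lower number here means that less compound is tolerated, a higher number that more compound is tolerated), returns only a limit of the assay, > 20 ug/mL (the limit of > 20 ug/mL in this assay, at which 1 of the 3 values shown sits). Compound 2 `Cc1cc(Sc2ccc(O)cc2)cn2c(CSCCc3ccccc3)cnc12` gives 4 ug/mL in this assay. Within the data shown here, the single one-place change measured is an at least 5.0-fold lower number from compound 1 to compound 2 (0.69 log units; beyond the scatter), and it is at least modest. Compound 3 `Cc1cc(-c2ccco2)c2ncc(CSCCc3ccccc3)n2c1` gives 100 ug/mL in this assay, the highest of the two numbers; the value of compound 2 sits lower, beyond the scatter. Compound 1, for its part, contributes only a limit and no number.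

Compound 4 `Cc1cc(N2CCCC2=O)c2ncc(CSCCc3ccccc3)n2c1` is not yet measured. Its change from compound 3 is 2-oxopyrrolidin-1-yl in place of furan-2-yl on an aromatic carbon. Among the measured compounds shown here, no measured step covers this exchange: the one step known, running from compound 1 to compound 2, swaps groups at a different ring carbon and lowered the number. It gives no direct guidance, so the expected step is one within the scatter, no change at the digits printed from compound 3 to compound 4 (within the scatter). Compound 4 is accordingly estimated at 100 ug/mL, with a range from 35 ug/mL to 200 ug/mL.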

Compound 4, minimum cytotoxic concentration: 20 ug/mL
Beside the measured number, compound 4's estimate is 5.0-fold (0.70 log units) above it; the whole stated range lies above it.
By their numbers in this assay, from the lowest: compound 2; then compound 4; then compound 3.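

At this position, an aromatic carbon ortho to a fused ring and meta to a methyl group, the exchange of furan-2-yl for 2-oxopyrrolidin-1-yl moves the read-out in this assay: a 5.0-fold lower number from compound 3 to compound 4 (0.70 log units; beyond the scatter). Among these compounds, the only earlier step lay at a different ring carbon, so this carbon now also shows sensitivity to its substituent. Both groups carry the same counts of hydrogen-bond donors and acceptors and no net charge, so those counts do not separate them, and nothing measured here gives a cause for the step.

Still open, from the compounds shown here alone, is whether the lower number goes with the loss of the aromatic ring or with the carbonyl of the lactam. A plain pyrrolidin-1-yl amine or a phenyl ring on the same carbon would help separate these two readings.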